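Compound 3 to compound 4: toxicity at the limit

The source may report more compounds than this note shows. Statements on the series, on what has been measured and on what is new or still open speak of the compounds shown alone.

Compound 1 `CCOC(=O)c1cnc2ccc(-c3ccc(N)cc3)cc2c1` gives > 7400 nM as a limit
Compound 2 `Cc1ccc(-c2ccc3ncc(-c4noc(C(F)(F)F)n4)cc3c2)cc1` gives > 22200 nM as a limit
Compound 3 `FC(F)(F)c1nc(-c2cnc3ccc(-c4ccccc4)cc3c2)no1` gives > 22200 nM as a limit

All three were tested in a functional assay on RD cells (Homo sapiens) for inhibition, read by luminescence and ATP content, with a stated time of 72 h (on this read-out lower numbers stand for higher toxicity in this test and higher numbers for lower toxicity in this test), and none of them has yet given a number. Compound 3 stands at > 22200 nM and that is a limit. Compound 4 `CN(C)c1ccc(-c2ccc3ncc(-c4noc(C(F)(F)F)n4)cc3c2)cc1` turns its phenyl into 4-(dimethylamino)phenyl, with dimethylamino in place of hydrogen on an aromatic carbon, para to a large group (dimethylamino in place of hydrogen on an aromatic carbon). For the measured compounds named here, the one measured step that bears on this is a step that the two limits leave unreadable from compound 2 to compound 3 and it offers no size to carry over. The change itself has not been measured in this assay on any pair of compounds. With only limits to go on, no step beyond the scatter is expected, in either direction. The expected step is a number no higher from compound 3 to compound 4 (the limit leaves the size open) and it rests on the limit of compound 3 at > 22200 nM as its only anchor. Compound 4 is estimated at 22200 nM with an expected range from 9000 nM to 50000 nM and it may well return only a limit.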

Compound 4, half-maximal cytotoxic concentration: > 22200 nM
Compound 4: a limit, no number; the forecaster's own chance of this, stated with the estimate: 70%; the middle value sits exactly at the limit.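

In this assay compound 4 gives > 22200 nM, which is a limit. No new step can be read: the steps to compound 4 from compound 2 and from compound 3 join limits only. The compounds shown leave open what dimethylamino changes in this assay, and at what concentration any of these compounds would turn toxic.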